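The compounds below may be only part of what the source reports. "The series", "measured", "known", "first", "only" and "open" are said of these compounds alone.

Compound 1 `O=C(Nc1cccc(CNc2nccnc2Cl)c1)NC1CCCC1`: in a functional assay on T-24 cells (Homo sapiens) for antiproliferative activity, read by MTT assay, with a stated time of 48 h (on this read-out lower numbers stand for stronger inhibition and higher numbers for weaker inhibition), compound 1 gives > 40000 nM, which is a limit of the assay and not a number.
Compound 2 `O=C(Nc1cccc(CNc2nccnc2Cl)c1)Nc1cccc(C(F)(F)F)c1`: in this assay compound 2 gives 5080 nM.

Of the two measured compounds, compound 1 sits at the limit of > 40000 nM in this assay, at which 1 of the 2 values shown sits, so its position on the scale is known only as a limit. Compound 2, carrying an aryl group on the urea nitrogen instead of the cyclopentyl of compound 1, does return a number, and that number is well inside the range the assay can resolve.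

Compound 3 `Cc1ccc(NC(=O)Nc2cccc(CNc3nccnc3Cl)c2)cc1` has not yet been measured in this assay. The change from compound 1 is 4-methylphenyl in place of cyclopentyl on an amide-type nitrogen. Cut one bond further out, it reads: cyclopentylamino to (4-methylphenyl)amino.

For the measured compounds named here, no step between measured compounds is available to set the size of this change. Going by the values given here, the one number at hand, compound 2 with its aryl urea at 5080 nM, suggests that a six-membered aromatic ring of carbon only on this nitrogen can bring the value into the measurable range. For compound 3 a step of an at least 5.0-fold lower number from compound 1 to compound 3 (0.69 log units; beyond the scatter) is expected, towards stronger inhibition. Compound 3 is estimated at 8000 nM, in the range 2500 nM to 30000 nM.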

Compound 3, half-maximal inhibitory concentration: 9820 nM
For compound 3 the middle estimate is 1.2-fold (0.09 log units) below the measured one; low and high end bracket the measured number.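

Placing 4-methylphenyl instead of cyclopentyl on the amide-type nitrogen gives an at least 4.0-fold lower number from compound 1 to compound 3 (0.60 log units; beyond the scatter), towards stronger inhibition in this assay. With compound 2 at 5080 nM and compound 3 at 9820 nM, two different aryl groups on this nitrogen now return numbers, so a measurable value here does not depend on the trifluoromethyl group of compound 2 alone. The step gives only a minimum size, as compound 1 stands at a limit and not at a number: the limit of > 40000 nM in this assay, at which 1 of the 3 values shown sits.

The change from compound 1 to compound 3 alters ring size, aromatic character and the methyl group all at once, and the compounds shown cannot separate these, so a cyclohexyl or an unsubstituted phenyl group on the same nitrogen would be needed to tell which of them matters. On these data alone, it also remains open how this nitrogen tolerates a ring containing nitrogen, such as pyridyl, or an aryl group carrying an amine or a carboxylic acid, and whether any such group would bring the value in this assay well beyond that of compound 3.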